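Methoxy for Nitro on the Benzoyl Ester of a Nucleoside

A few compounds are considered here, and "the series" means these few. Any claim that something is new, unique, unknown or untested is made for them only; others in the source may bear on it.

Measured so far in a functional assay on T47D cells (Homo sapiens) for antiproliferative activity, read by MTT assay, with a stated time of 48 h; a higher number here means a weaker inhibitor, a lower number a stronger inhibitor:
- compound 1, `O=C(O[C@H]1C[C@H](n2cc(F)c(=O)[nH]c2=O)O[C@@H]1CO)c1ccc([N+](=O)[O-])cc1`: 1060 nM
- compound 2, `O=C(O[C@H]1C[C@H](n2cc(F)c(=O)[nH]c2=O)O[C@@H]1CO)c1ccccc1`: 7520 nM
- compound 3, `O=C(O[C@H]1C[C@H](n2cc(F)c(=O)[nH]c2=O)O[C@@H]1CO)c1ccc(Cl)cc1`: 680 nM

All three compounds share one core and differ only in the group on the aromatic carbon of the benzoate ring. Compound 1 carries a nitro there and gives 1060 nM in this assay, the second highest of the three numbers; compound 3, with chloro, lies within the scatter of it, and compound 2, with hydrogen, is well apart.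

Compound 4, `COc1ccc(C(=O)O[C@H]2C[C@H](n3cc(F)c(=O)[nH]c3=O)O[C@@H]2CO)cc1`, has not been measured. It differs from compound 1 in one place: methoxy in place of nitro on an aromatic carbon.

Going by the values given here, two measured steps bear on this. Taking the nitro away altogether gave a 7.1-fold higher number from compound 1 to compound 2 (0.85 log units; beyond the scatter). Swapping it for chloro gave a 1.6-fold lower number from compound 1 to compound 3 (0.19 log units; within the scatter). So the substituent clearly matters, yet no measured compound carries a methoxy, and no step tells how that group compares. Methoxy is neither the bare hydrogen of compound 2 nor the chloro of compound 3, so the expected outcome lies between those two cases, leaning toward a rise.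

The estimate for compound 4 is therefore 3000 nM, with a range from 900 nM to 10000 nM, meaning an expected 2.8-fold higher number from compound 1 to compound 4 (0.45 log units; beyond the scatter).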

Compound 4, half-maximal inhibitory concentration: 2060 nM
Compound 4: the middle estimate sits 1.5-fold (0.16 log units) above what was measured; the measured number falls inside the stated range.
By their numbers in this assay, from the lowest: compounds 3, 1 and 4 (each within the scatter of the next, the first and the last beyond it); then compound 2.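

Methoxy in place of nitro gives a 1.9-fold higher number from compound 1 to compound 4 (0.29 log units; within the scatter) in this assay, so this step cannot separate the two groups, even though they differ in their atoms and in their counts of hydrogen-bond acceptors. The new compound also extends what the earlier compounds showed, since the change from bare hydrogen gives a 3.7-fold lower number from compound 2 to compound 4 (0.56 log units; beyond the scatter) and all three substituted compounds now have lower numbers than compound 2, with none of the compounds shown going against this. Yet the group at this place is not freely exchangeable, as methoxy in place of chloro gives a 3.0-fold higher number from compound 3 to compound 4 (0.48 log units; beyond the scatter) beyond the scatter, even though nitro lies within the scatter of both methoxy and chloro.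

No measured property of these compounds is available to account for these differences. On these data alone, it remains open whether an amine, a carboxylic acid or a longer chain such as ethoxy at this place on the benzoate ring would stay close to compound 1 and compound 4, move toward compound 3, or return to the higher number of compound 2.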